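Adding a Second Chloro to a Near-Limit Urea

This account rests on a few compounds, and the source may have more. Where it says the series, first, only, none or still open, it means among the compounds named here.

compound 1: `CNc1cc(Oc2ccc(NC(=O)Nc3cccc(C(F)(F)F)c3)cc2Cl)ncn1` — 50 nM
compound 2: `CNc1cc(Oc2ccc(NC(=O)Nc3cccc(C(F)(F)F)c3)cc2C)ncn1` — <= 10 nM

Compound 1 `CNc1cc(Oc2ccc(NC(=O)Nc3cccc(C(F)(F)F)c3)cc2Cl)ncn1` and compound 2 `CNc1cc(Oc2ccc(NC(=O)Nc3cccc(C(F)(F)F)c3)cc2C)ncn1` share one core and differ at a single aromatic carbon, where the chloro of compound 1 is replaced by a methyl in compound 2. In an assay on isolated protein for inhibition of serine/threonine-protein kinase TNNI3K (Homo sapiens) (a lower number here means a stronger inhibitor, a higher number a weaker inhibitor), compound 1 gives 50 nM. Compound 2 gives <= 10 nM in this assay, and this figure is a limit of the assay rather than a measured number. The step of an at least 5.0-fold lower number from compound 1 to compound 2 (0.69 log units; beyond the scatter) thus places compound 2 as the stronger inhibitor, although its exact position is bounded only from one side, as the limit of <= 10 nM in this assay, at which 1 of the 2 values shown sits, shows.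

Compound 3 `CNc1cc(Oc2c(C)cc(NC(=O)Nc3cccc(C(F)(F)F)c3)cc2Cl)ncn1` keeps everything of compound 2 and adds one change: chloro in place of hydrogen on an aromatic carbon. Among the measured compounds shown here, no measured step touches this position; the only measured step concerns a different carbon of the same ring. The measured compounds therefore give no direction for this change, and the sensible expectation is a number close to where compound 2 stands. Compound 3 is expected to land at 15 nM, with a range from 4 nM to 60 nM. The step this estimate implies is expected to be an at least 1.5-fold higher number from compound 2 to compound 3 (0.17 log units; that floor lies within the scatter).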

Compound 3, half-maximal inhibitory concentration: 79 nM
Estimate against measurement, compound 3: 5.3-fold (0.72 log units) below, outside the stated range (above it).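

In this assay, the ring carbon ortho to the (6-(methylamino)pyrimidin-4-yl)oxy group turns out to matter once the methyl is in place: putting chloro there in place of hydrogen gives an at least 7.9-fold higher number from compound 2 to compound 3 (0.89 log units; beyond the scatter). Seen from the other side, putting methyl in place of hydrogen on the chloro compound gives a 1.6-fold higher number from compound 1 to compound 3 (0.20 log units; within the scatter), so the advantage of methyl over chloro seen earlier does not carry over to a ring holding both groups, and the two changes do not simply add up. The cost of the added chloro is known only as a floor, and its full size stays hidden: the limit of <= 10 nM in this assay, at which 1 of the 3 values shown sits.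

These three compounds cannot tell whether that cost belongs to chloro itself or would come with any group on this carbon, and a fluoro or a methoxy group at the same place would help separate the two. They also leave open how a compound with hydrogen on both of these ring carbons would rank, so neither the chloro nor the methyl can yet be compared with a bare ring.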